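Hydroxyethylamino in place of sulfanyl on the shared core

The source may report more compounds than this note shows. Statements on the series, on what has been measured and on what is new or still open speak of the compounds shown alone.

Compound 3 `Sc1[nH]ccc2ncnc1-2` stands at a limit of a functional assay on EL4 cells (Mus musculus) for inhibition, tested at 100 uM; a higher number here means more inhibition at the concentration tested (going by the name of the read-out), a lower number less inhibition: compound 3 gives < 5%, which is a limit and not a number. Compound 2 `Clc1[nH]ccc2ncnc1-2` likewise gives < 5%, also a limit. The step that the two limits leave unreadable from compound 2 to compound 3 is therefore unreadable, and the limit of < 5% in this assay, at which 2 of the 3 values shown sit, applies to both. Compound 1 `CCCCCCNc1[nH]ccc2ncnc1-2` gives 100% in this assay. Compound 4 `OCCNc1[nH]ccc2ncnc1-2` differs from compound 3 by (2-hydroxyethyl)amino in place of sulfanyl on an aromatic carbon. Going by the values given here, no measured step covers this exact change; the only readable point is that compound 1, which carries an amino substituent, reaches 100%. Compound 2 and compound 3 do not leave the limit. The step expected for a number at least 40 percentage points higher from compound 3 to compound 4 (beyond the scatter) is upward, with wide uncertainty. Compound 4 is estimated at 45%, between 5% and 95%.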

Compound 4, a percentage reported as inhibition, at one concentration (the size of the read-out at that concentration, not a potency): < 5%
Compound 4 was reported as a limit; the forecaster's own chance of this, stated with the estimate: 30%; middle value at least 40 percentage points away from the limit.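

In this assay an amino substituent on the aromatic carbon is not enough on its own: hydroxy in place of butyl on the saturated chain carbon, two bonds along the chain from a nitrogen on an aromatic ring, gives a number at least 95 percentage points lower from compound 1 to compound 4 (beyond the scatter). Compound 4 gives < 5%, which is a limit and not a number. The steps to compound 4 from compound 2 and compound 3 cannot be read: the limit of < 5% in this assay, at which 3 of the 4 values shown sit.

Open, on these data alone, is how a shorter alkyl chain, or a chain ending in an amine or a carboxylic acid, would stand against compound 1 and compound 4.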